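Series notes: aryl swap at the pyrazole position

The compounds below may be only part of what the source reports. "The series", "measured", "known", "first", "only" and "open" are said of these compounds alone.

The shared core of compound 1 `Cc1nn(-c2nc(-c3ccc(Cl)c(Cl)c3)c(SC(C)C)s2)c(C(=O)O)c1-c1cc(C#N)cc(C(F)(F)F)c1` carries a 3-cyano-5-(trifluoromethyl)phenyl group on an aromatic carbon of the five-membered ring with two nitrogens. In a functional assay on BJAB cells (Homo sapiens) for antiproliferative activity, with a stated time of 4 days (on this read-out lower numbers stand for an effect already at smaller amounts and higher numbers for an effect only at larger amounts of compound), compound 1 gives 3600 nM. Compound 2 `Cc1nn(-c2nc(-c3ccc(Cl)c(Cl)c3)c(SC(C)C)s2)c(C(=O)O)c1-c1cc(C(F)(F)F)cc(C(F)(F)F)c1` gives 1800 nM in this assay; the two numbers lie within the scatter of each other, so compound 1 cannot be set apart from compound 2. Compound 3 `Cc1c(-c2cc(Cl)cc(Cl)c2)c(C(=O)O)nn1-c1nc(-c2cnn(C)c2)c(SC(C)C)s1` was reported as "not active" (no number reported) in this assay, without a number.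

Compound 4 `Cc1nn(-c2nc(-c3ccc(Cl)c(Cl)c3)c(SC(C)C)s2)c(C(=O)O)c1-c1ccc(C(F)(F)F)cc1` differs from compound 1 in one place: 4-(trifluoromethyl)phenyl in place of 3-cyano-5-(trifluoromethyl)phenyl on an aromatic carbon. Going by the values given here, no measured step covers exactly this change. Among the compounds with values here, the only step at this position, a 2.0-fold lower number from compound 1 to compound 2 (0.30 log units; within the scatter), exchanged cyano for trifluoromethyl and stayed within the scatter. Within the data shown here, removing the nitrile and placing a single trifluoromethyl has no measured counterpart here, so no step beyond the scatter is expected in this assay, with a wide range to reflect the missing precedent. For compound 4 the expected value in this assay is 4000 nM (range 1500 nM to 12000 nM), which means an expected step of a 1.1-fold higher number from compound 1 to compound 4 (0.05 log units; within the scatter).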

Compound 4, half-maximal effective concentration: 3500 nM
Compound 4: the middle estimate sits 1.1-fold (0.06 log units) above what was measured; measured number inside the range.
By their numbers in this assay, from the lowest: compounds 2, 4 and 1 (each within the scatter of the next).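

In this assay the exchange of 3-cyano-5-(trifluoromethyl)phenyl for 4-(trifluoromethyl)phenyl gives a 1.0-fold lower number from compound 1 to compound 4 (0.01 log units; within the scatter), so this pair shows no readable difference. The earlier step replaced the nitrile with a second trifluoromethyl and kept two substituents on the phenyl; this one removes the nitrile and leaves a single trifluoromethyl in a different place on the ring, and the read-out still stays within the scatter for compound 1 and compound 4. No supporting data explain this result.

From the compounds shown here alone, what an unsubstituted phenyl, a phenyl bearing an amine or a cyclohexyl ring would give on this aromatic carbon remains open. Also open, going by these compounds, is whether the same exchange behaves alike when the 3,4-dichlorophenyl group of the shared core is replaced.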